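The source may report more compounds than this note shows. Statements on the series, on what has been measured and on what is new or still open speak of the compounds shown alone.

Compound 1 `C/N=C(/NC#N)NCCCCCCn1nc(-c2ccccc2)ccc1=O` carries a methyl-substituted cyanoguanidine on a six-carbon chain attached to the shared core. In a functional assay on the whole organism with Rattus norvegicus as the target (a higher number here means that more compound is needed for the effect, a lower number that less compound is needed), compound 1 reaches only the limit of the assay, > 100 mg/kg, which is a limit and not a measured number; it sits at the limit of > 100 mg/kg in this assay, at which 1 of the 3 values shown sits. Compound 4 `CN(C)/C(=N/CCCCCCn1nc(-c2ccccc2)ccc1=O)NC#N` differs from compound 1 by a group of 8 heavy atoms (4 carbon, 4 nitrogen; no ring) in place of a group of 7 heavy atoms (3 carbon, 4 nitrogen; no ring), on a saturated chain carbon, six bonds along the chain from an aromatic nitrogen. Among the measured compounds, compound 2 `C=CCNC(=S)NCCCCn1nc(-c2ccccc2)ccc1=O` gives 78.6 mg/kg and compound 3 `CN(C)/C(=N/CCCn1nc(-c2ccccc2)ccc1=O)NC#N` gives 93.1 mg/kg. Going by the values given here, the one measured step, a 1.2-fold higher number from compound 2 to compound 3 (0.07 log units; within the scatter), exchanges a thiourea for the same dimethyl cyanoguanidine that enters compound 4, but on a shorter chain and starting from a different group, so it speaks only indirectly to the change leading to compound 4. Among the compounds with values here, no measured pair shows the swap of a methyl-substituted cyanoguanidine for the dimethyl one on the same chain. The change is therefore expected to amount to a step that the limit leaves unreadable from compound 1 to compound 4, staying within the scatter, with the added uncertainty that the starting point is known only as a limit. Compound 4 is accordingly estimated at 120 mg/kg, in a range from 60 mg/kg to 250 mg/kg.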

Compound 4, dose for half-maximal effect: 92.5 mg/kg
Estimate against measurement, compound 4: 1.3-fold (0.11 log units) above, within the range that was stated.
By their numbers in this assay, from the lowest: compounds 2, 4 and 3 (each within the scatter of the next). At a limit, above all of these: compound 1.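

Going by these compounds alone, this is the first pair in which the chain stays the same and only the end group changes, and in this assay it gives an at least 1.0-fold lower number from compound 1 to compound 4 (0.03 log units; that floor lies within the scatter). How far this change really moves the number cannot be read from that step, because compound 1 is known only as a limit and not as a number: the limit of > 100 mg/kg in this assay, at which 1 of the 4 values shown sits. What is new is that the dimethyl cyanoguanidine, which carries 1 hydrogen-bond donor where the group it replaces carries 2, now has a measured value on both chains: on the shorter chain compound 3 gives 93.1 mg/kg, on the chain of six bonds compound 4 gives 92.5 mg/kg, and these two values lie within the scatter of each other.

The compounds shown leave open what the thiourea of compound 2 would give at the place six bonds along the chain from an aromatic nitrogen, where it could be set directly against compound 4. They also leave open what an amine or a carboxylic acid would give in place of the cyanoguanidine, and how a longer chain would affect the dose needed.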